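The source may hold more compounds than are shown below. What is called first, only, known or untested is meant among the compounds shown, and "the series" means these compounds.

Within the data shown here, compound 1 `Clc1ccc(Nc2nc(-c3ccccn3)cs2)nc1` is one of two compounds measured in an ADME assay on KB cells (Homo sapiens) for cytotoxicity, read by MTT assay, with a stated time of 72 h; on this read-out higher numbers stand for lower toxicity in this test and lower numbers for higher toxicity in this test; compound 1 gives 98600 nM. Compound 2 `COc1ccc(-c2csc(Nc3ccc(Cl)cn3)n2)nc1` gives 59600 nM in this assay, and the step of a 1.7-fold lower number from compound 1 to compound 2 (0.22 log units; within the scatter) is within the scatter, so the two numbers are not distinguished. Compound 3 `Clc1ccc(Nc2nc(-c3cccnn3)cs2)nc1` differs from compound 1 by pyridazin-3-yl in place of pyridin-2-yl on an aromatic carbon. Among the measured compounds shown here, no measured step bears on this change; the only step known, methoxy in place of hydrogen on an aromatic carbon, concerns a different position. No step beyond the scatter is therefore expected in this assay. Compound 3 is estimated at 90000 nM, range 40000 nM to 200000 nM, an expected step of a 1.1-fold lower number from compound 1 to compound 3 (0.04 log units; within the scatter).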

Compound 3, half-maximal cytotoxic concentration: 10300 nM
Compound 3: middle estimate off by 8.7-fold (0.94 log units), on the high side; measured number outside the range, below it.
By their numbers in this assay, from the lowest: compound 3; then compounds 2 and 1 (each within the scatter of the next).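

At this position, next to the ring nitrogen, pyridazin-3-yl in place of pyridin-2-yl gives a 9.6-fold lower number from compound 1 to compound 3 (0.98 log units; beyond the scatter) in this assay, which means higher toxicity in this test. Among these compounds, this is the first step beyond the scatter, and it shows that the number responds to a change of the aromatic ring at this place, with the count of heavy atoms unchanged. Nothing available accounts for the step. Still open, on these data alone, is whether pyrimidin-2-yl or pyrazin-2-yl here would give a step of similar size, and where phenyl would fall.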